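Swapping the Benzylic Aryl: Solubility Outlook for Compound 3

The source may hold more compounds than are shown below. What is called first, only, known or untested is meant among the compounds shown, and "the series" means these compounds.

Measured in a physicochemical assay for solubility, with a stated time of 18 h, at pH 7.4; on this read-out higher numbers stand for higher solubility and lower numbers for lower solubility:
compound 1 `CCC(CC)c1ccc2c(NCCCNCc3cccc(OC)c3O)ccnc2c1`: 4200 nM
compound 2 `COc1cccc(CNCCCNc2ccnc3cc(Cc4ccc(F)cc4Cl)ccc23)c1O`: 4200 nM

For the measured compounds named here, compound 1 stands level with compound 2 in this assay; the single measured step, no change at the digits printed from compound 1 to compound 2 (within the scatter), lies within the scatter and concerns a different part of the molecule. Compound 3 `CCC(CC)c1ccc2c(NCCCNCc3ccco3)ccnc2c1` differs from compound 1 as follows: furan-2-yl in place of 2-hydroxy-3-methoxyphenyl on a saturated chain carbon bound to an amine nitrogen. Going by the values given here, no measured step alters the 2-hydroxy-3-methoxybenzyl part, so the data give no direct guide to this change. The estimated no change at the digits printed from compound 1 to compound 3 (within the scatter) is therefore expected to stay within the scatter. Compound 3 is estimated at 4200 nM, with a range from 1500 nM to 12000 nM.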

Compound 3, solubility: 4200 nM
For compound 3 middle estimate and measured number coincide at the digits printed; low and high end bracket the measured number.
By their numbers in this assay, from the lowest: compounds 1, 2 and 3 (each within the scatter of the next).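

For the compounds shown here, at the saturated chain carbon bound to an amine nitrogen, where the earlier compounds offered no step, this assay gives no change at the digits printed from compound 1 to compound 3 (within the scatter) for furan-2-yl in place of 2-hydroxy-3-methoxyphenyl. Thus, at this place, going from 9 heavy atoms and 1 hydrogen-bond donor to 5 heavy atoms and 0 donors leaves the read-out within the scatter. No available evidence accounts for this result. Still open, as far as these compounds go, is how a carboxylic acid or a morpholine ring would read at this place, and whether furan-2-yl would read the same on the core of compound 2.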